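Moving the Methoxy Group on the Ether-Linked Phenyl Ring

A few compounds are considered here, and "the series" means these few. Any claim that something is new, unique, unknown or untested is made for them only; others in the source may bear on it.

Three compounds sharing one core were compared in an assay for inhibition of prostacyclin synthase (Homo sapiens), using microsomes; a higher number here means a weaker inhibitor, a lower number a stronger inhibitor. Compound 1, `N#Cc1ccc(C2OCC(C/C=C\CCC(=O)O)C(c3cccnc3)O2)cc1`, reaches only a limit of this assay, > 100000 nM. Compound 2, `O=C(O)CC/C=C\CC1COC(c2ccc([N+](=O)[O-])cc2)OC1c1cccnc1`, gives 13000 nM in this assay. Among the compounds with values here, the change an at least 7.6-fold lower number from compound 1 to compound 2 (0.88 log units; beyond the scatter) is the only measured step. Compound 3, `COc1ccc(OC(C)(C)C2OCC(C/C=C\CCC(=O)O)C(c3cccnc3)O2)cc1`, likewise sits at a limit of this assay, > 100000 nM. Two of the three values thus rest at the limit of > 100000 nM in this assay, at which 2 of the 3 values shown sit, so compound 3 is known only as a weak inhibitor. Compound 4, `COc1ccccc1OC(C)(C)C1OCC(C/C=C\CCC(=O)O)C(c2cccnc2)O1`, differs from compound 3 by 2-methoxyphenyl in place of 4-methoxyphenyl on an oxygen on a saturated carbon. Within the data shown here, the single measured step concerns a different place in the molecule and does not bear on this change, so no shift beyond the scatter is expected. Compound 4 is therefore estimated at 100000 nM, between 30000 nM and 300000 nM. The expected step is a number no higher from compound 3 to compound 4 (the limit leaves the size open), most likely again only a limit of this assay.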

Compound 4, half-maximal inhibitory concentration: 51000 nM
Estimate against measurement, compound 4: 2.0-fold (0.29 log units) above, within the range that was stated.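

The change gives an at least 1.9-fold lower number from compound 3 to compound 4 (0.29 log units; that floor lies within the scatter), so the move of the methoxy group is not shown to exceed the scatter, although the true step could be larger. Within the data shown here, compound 4 is the first compound here with a methoxyphenyl ether to give a true number rather than a limit, 51000 nM. Compound 3 remains at a limit, and the size of the step stays open because of that: the limit of > 100000 nM in this assay, at which 2 of the 4 values shown sit.

Still open, going by these compounds, is how an amine or a carboxylic acid in place of the methoxy group on this ring would affect the number.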